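Trimming a Methoxy Group from Compound 3

The compounds below may be only part of what the source reports. "The series", "measured", "known", "first", "only" and "open" are said of these compounds alone.

Compound 1, `COc1cc(-c2cc(/C=C/C(=O)c3ccc(N)cc3)[nH]n2)cc(OC)c1OC`: in a functional assay on HT-29 cells (Homo sapiens) for inhibition, read by sulforhodamine B assay, with a stated time of 48 h (on this read-out higher numbers stand for lower toxicity in this test and lower numbers for higher toxicity in this test), compound 1 reaches only the assay limit > 100000 nM.
Compound 2, `COc1ccc(-c2cc(/C=C/C(=O)c3ccc(N)cc3)[nH]n2)cc1OC`: in this assay compound 2 gives 58900 nM.
Compound 3, `COc1cc(C(=O)/C=C/c2cc(-c3cc(OC)c(OC)c(OC)c3)n[nH]2)cc(OC)c1OC`: in this assay compound 3 gives 6360 nM.

Within the data shown here, the value of compound 1 is a limit of the assay rather than a number, and it is the single value sitting at the limit of > 100000 nM in this assay, at which 1 of the 3 values shown sits. Compound 2 differs from compound 1 by hydrogen in place of methoxy on an aromatic carbon, and the step of an at least 1.6-fold lower number from compound 1 to compound 2 (0.22 log units; that floor lies within the scatter) is only a floor, one that lies within the scatter. Among the measured compounds shown here, compound 3 has the lowest number of the two numbers measured so far; its nearest neighbour is compound 2, and the gap between the two lies beyond the scatter. The difference between the core of compound 3 and the core of compound 1 is not broken down here.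

Compound 4, `COc1ccc(-c2cc(/C=C/C(=O)c3cc(OC)c(OC)c(OC)c3)[nH]n2)cc1OC`, has not yet been measured. It differs from compound 3 by hydrogen in place of methoxy on an aromatic carbon, the same change as from compound 1 to compound 2, in the same surroundings. Since the earlier step of an at least 1.6-fold lower number from compound 1 to compound 2 (0.22 log units; that floor lies within the scatter) reached only a floor within the scatter, the expected step for compound 4 is a 1.4-fold lower number from compound 3 to compound 4 (0.15 log units; within the scatter), small and uncertain in direction. Compound 4 is therefore estimated at 4500 nM, with the expected range running from 1500 nM to 15000 nM.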

Compound 4, concentration lethal to 50% of the cells: 5750 nM
Beside the measured number, compound 4's estimate is 1.3-fold (0.11 log units) below it, and the stated range covers the measured number.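

On the core of compound 3, the change of methoxy to hydrogen can be read in full in this assay, and the step is a 1.1-fold lower number from compound 3 to compound 4 (0.04 log units; within the scatter), so compound 4 cannot be told apart from compound 3 on this read-out. Set beside the earlier case, this gives the only comparison of the change across cores available in the series: the same change on two cores in this assay, an at least 1.6-fold lower number (0.22 log units; that floor lies within the scatter) from compound 1 to compound 2 and a 1.1-fold lower number (0.04 log units; within the scatter) from compound 3 to compound 4; the limit leaves it open whether they differ. The value of compound 1, > 100000 nM, is a limit of the assay and not a number, which leaves the size of the change on that core unknown; the two pairs are therefore consistent with a small effect on both cores, but they do not show that the effect is the same on both or that it would hold on any further core.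

The compounds shown leave open whether a hydroxy group, a fluorine atom or an ethoxy group in place of that methoxy would move the number away from that of compound 3 in this assay. They also leave open whether the same change of methoxy to hydrogen on the other six-membered aromatic ring of carbon only in compound 3 would be as small.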